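The compounds below may be only part of what the source reports. "The series", "measured", "known", "first", "only" and "open" are said of these compounds alone.

Working notes on the series, ester-linked amides on a shared core.

Three compounds carry a number in an assay on isolated protein for inhibition of glutathione S-transferase Mu 2 (Homo sapiens), with a stated time of 10 min (on this read-out higher numbers stand for weaker inhibition and lower numbers for stronger inhibition), so far. Compound 1 `O=C(CCC(=O)OCCCCCCSc1ccc([N+](=O)[O-])c2nonc12)Nc1ccc(F)cc1` gives 320 nM in this assay. Compound 2 `CN(C)CCCNC(=O)CCC(=O)OCCCCCCSc1ccc([N+](=O)[O-])c2nonc12` gives 90 nM in this assay. Compound 3 `O=C(CCC(=O)OCCCCCCSc1ccc([N+](=O)[O-])c2nonc12)NCCN1CCCC1` gives 200 nM in this assay, the second highest of the three numbers: it sits nearest compound 1 (a 1.6-fold lower number from compound 1 to compound 3 (0.20 log units; within the scatter)) and furthest from compound 2 (a 2.2-fold higher number from compound 2 to compound 3 (0.35 log units; beyond the scatter)). Among the measured compounds shown here, the only other step across the set, a 3.6-fold lower number from compound 1 to compound 2 (0.55 log units; beyond the scatter), is likewise modest. For the measured compounds named here, all variation so far is confined to the group on the amide-type nitrogen.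

Compound 4 `O=C(CCC(=O)N1CCOCC1)OCCCCCCSc1ccc([N+](=O)[O-])c2nonc12` is not yet measured in this assay. It differs from compound 3 in that same region: morpholin-4-yl in place of (2-(pyrrolidin-1-yl)ethyl)amino on a carbonyl carbon. The three measured steps bear on it only loosely, since none of them replaces the amide hydrogen and the attached chain with a ring directly on the carbonyl carbon. Their sizes suggest that changes at this position move the number by modest amounts in either direction. A modest rise is therefore expected, toward or past compound 1, with the step of a 2.0-fold higher number from compound 3 to compound 4 (0.30 log units; within the scatter) expected. For compound 4 the estimate in this assay is 400 nM, expected to fall between 150 nM and 1100 nM.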

Compound 4, half-maximal inhibitory concentration: 170 nM
The estimate for compound 4 lay 2.4-fold (0.37 log units) above the measured number; measured number inside the range.
By their numbers in this assay, from the lowest: compounds 2, 4, 3 and 1 (each within the scatter of the next, the first and the last beyond it).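

Placing morpholin-4-yl directly on the carbonyl carbon removes the amide hydrogen and the attached group together, yet in this assay the result stays within the scatter of all three compounds that keep that hydrogen (a 1.2-fold lower number from compound 3 to compound 4 (0.07 log units; within the scatter); a 1.9-fold higher number from compound 2 to compound 4 (0.28 log units; within the scatter); a 1.9-fold lower number from compound 1 to compound 4 (0.27 log units; within the scatter)). The other three compounds all had a secondary amide, so they could not show that, among these four compounds, a number in this range needs neither the amide hydrogen nor a chain or aryl group on the amide-type nitrogen, while the step from compound 1 to compound 2 remains the only one beyond the scatter apart from that between compound 2 and compound 3. No measurement at hand accounts for this result.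

Still open, as far as these compounds go, is whether the morpholin-4-yl oxygen matters, which piperidin-1-yl or dimethylamino on the same carbonyl carbon would test, and whether a carboxylic acid in place of the amide stays in this range. The four compounds also share the ester link and the core of compound 1, so a longer chain between the two carbonyl groups or an amide in place of the ester remains unaddressed.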